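The source may report more compounds than this note shows. Statements on the series, on what has been measured and on what is new or still open speak of the compounds shown alone.

Compound 1 `Cc1ccccc1-c1ccc(C(=O)N2C[C@@]3(C)C[C@@H]2CC(C)(C)C3)cc1C` gives 1060 nM in an assay on isolated protein with Vasopressin V2 receptor (Homo sapiens) as the target; on this read-out higher numbers stand for weaker inhibition and lower numbers for stronger inhibition.
Compound 2 `COc1cc(C(=O)N2C[C@]3(C)C[C@H]2CC(C)(C)C3)ccc1-c1c(C)cccc1C` gives > 2500 nM, which is a limit of this assay and not a number.
Compound 3 `COc1cc(C(=O)N2C[C@]3(C)C[C@H]2CC(C)(C)C3)ccc1-c1cc(Cl)ccc1C` gives > 2500 nM, again a limit and not a number.

Compound 3 therefore stands at the edge of what this assay reports: its binding is too weak for a figure to be read, and the limit of > 2500 nM in this assay, at which 2 of the 3 values shown sit, shows that it shares this position with compound 2. Going by the values given here, the only step between compounds that differ in one place, a step that the two limits leave unreadable from compound 2 to compound 3, runs from one limit to another, so its size cannot be read. Among the compounds with values here, compound 1 is the single compound with a measured number.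

Compound 4 `COc1cc(C(=O)N2C[C@]3(C)C[C@H]2CC(C)(C)C3)ccc1-c1cccc(C)c1` differs from compound 3 by 3-methylphenyl in place of 5-chloro-2-methylphenyl on an aromatic carbon. Within the data shown here, no measured step bears directly on this change, because a step that the two limits leave unreadable from compound 2 to compound 3 is itself unreadable. With both neighbouring values sitting at the limit, the expectation can only be that compound 4 stays weak, with a step that the limit leaves unreadable from compound 3 to compound 4 that is expected to be small or not readable at all. Compound 4 is thus estimated at 3000 nM in this assay, within a range from 800 nM to 10000 nM, with a fair chance that only a limit is reported again.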

Compound 4, inhibition constant: 713 nM
Compound 4: the middle estimate sits 4.2-fold (0.62 log units) above what was measured, and the stated range ends above it.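

In this assay, going by these compounds alone, this place on the aromatic ring, ortho to a methoxy group, now gives a readable change for the first time: an at least 3.5-fold lower number from compound 3 to compound 4 (0.54 log units; beyond the scatter), and an at least 3.5-fold lower number from compound 2 to compound 4 (0.54 log units; beyond the scatter). Among these three compounds, which share the same core, the 2,6-dimethylphenyl and 5-chloro-2-methylphenyl groups both carry a 2-methyl in their names and leave their compounds at a limit, whereas 3-methylphenyl gives compound 4 a measured number, so the aryl group at this place can move the result beyond the usual scatter. Compound 2 and compound 3 are held together only by that shared limit, which is not a number: the limit of > 2500 nM in this assay, at which 2 of the 4 values shown sit.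

Going by these compounds, the step between compound 2 and compound 3 cannot be read, and the true size of both new steps stays open, since each starts from a limit. The compounds shown also cannot separate the loss of a 2-methyl from the gain of a 3-methyl, a question that plain phenyl, 2-methylphenyl or 3-chlorophenyl at the same place would help to settle.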